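Removing the Ortho Substituent: From Trifluoromethyl to Hydrogen

The source may hold more compounds than are shown below. What is called first, only, known or untested is meant among the compounds shown, and "the series" means these compounds.

Measured compounds:
- Compound 1, `CCCc1nc(-c2ccccc2)c(CNCCN2CCN(c3ccccc3F)CC2)o1`: 46.5%
- Compound 2, `CCCc1nc(-c2ccccc2)c(CNCCN2CCN(c3ccccc3Cl)CC2)o1`: 60.1%
- Compound 3, `CCCc1nc(-c2ccccc2)c(CNCCN2CCN(c3ccccc3C(F)(F)F)CC2)o1`: 54.6%

All three share one core and differ only in the group on the aromatic ring attached to the piperazine. In an assay on HEK293 cells for inhibition of Voltage-dependent T-type calcium channel subunit alpha-1G (Homo sapiens), read by fluorescence, tested at 10 uM (a higher number here means more inhibition at the concentration tested (going by the name of the read-out), a lower number less inhibition), compound 3 gives 54.6%, the second highest of the three numbers; its gap to compound 2 and its gap to compound 1 both lie within the usual scatter, so no order among them is secure.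

Compound 4, `CCCc1nc(-c2ccccc2)c(CNCCN2CCN(c3ccccc3)CC2)o1`, carries hydrogen in place of trifluoromethyl on an aromatic carbon. Within the data shown here, no measured step removes a group entirely, so the nearest guidance comes from swaps among groups: a number 13.6 percentage points higher from compound 1 to compound 2 (beyond the scatter), a number 8.1 percentage points higher from compound 1 to compound 3 (within the scatter) and a number 5.5 percentage points lower from compound 2 to compound 3 (within the scatter). These show that exchanging one group for another moves the number at most modestly, and the small fluoro in compound 1 sits lowest. A hydrogen is smaller still, so a modest drop, or no change beyond the scatter, is expected.

The expected step is a number 9.6 percentage points lower from compound 3 to compound 4 (within the scatter). Compound 4 is estimated at 45%, with a likely range from 25% to 65%.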

Compound 4, a percentage reported as inhibition, at one concentration (the size of the read-out at that concentration, not a potency): 54.3%
The estimate for compound 4 lay 9.3 percentage points below the measured number, and the stated range covers the measured number.
By their numbers in this assay, from the lowest: compounds 1, 4, 3 and 2 (each within the scatter of the next, the first and the last beyond it).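

In this assay, removing the trifluoromethyl group altogether gives a number 0.3 percentage points lower from compound 3 to compound 4 (within the scatter), so a substituent on this aromatic carbon is not needed for the inhibition seen at the concentration tested. The unsubstituted phenyl of compound 4 also cannot be separated from either halogen compound, with a number 5.8 percentage points lower from compound 2 to compound 4 (within the scatter) and a number 7.8 percentage points higher from compound 1 to compound 4 (within the scatter), even though chloro and fluoro lie beyond the scatter of each other. No measurement shown here offers an explanation for this result.

Going by these compounds, it remains open whether a methoxy group, an amine or a carboxylic acid on this same carbon would shift the number beyond the scatter. A single-concentration percentage also leaves open how these compounds would rank by potency, which would take a full concentration series to establish.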